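Linker and aryl changes on the shared core: notes toward compound 3

This account rests on a few compounds, and the source may have more. Where it says the series, first, only, none or still open, it means among the compounds named here.

For the measured compounds named here, compound 2 `COc1cc(Cl)cc(-c2nn(-c3cccc(NC(=O)Nc4cccc(C(F)(F)F)c4)c3)cc2-c2ccncc2)c1` holds the lower of the two numbers so far in a functional assay on SF-295 cells (Homo sapiens) for inhibition, read by sulforhodamine B assay, with a stated time of 48 h, tested at 10 uM; a higher number here means a weaker effect of the compound at the concentration tested, a lower number a stronger effect: compound 2 gives -7.87%. Its nearest neighbour is compound 1 `COc1cc(Cl)cc(-c2nn(-c3cccc(NC(=O)c4ccc(Cl)c(Cl)c4)c3)cc2-c2ccncc2)c1`, which in this assay gives 36.1%. Going by the values given here, the single measured step, a number 44 percentage points lower from compound 1 to compound 2 (beyond the scatter), bundles two alterations at once, a different aryl group and the exchange of an aryl for an arylamino group on the carbonyl carbon, so the numbers at hand do not separate the two contributions.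

Compound 3 `COc1cc(Cl)cc(-c2nn(-c3cccc(NC(=O)c4cccc(C(F)(F)F)c4)c3)cc2-c2ccncc2)c1` differs from compound 2 by 3-(trifluoromethyl)phenyl in place of (3-(trifluoromethyl)phenyl)amino on a carbonyl carbon. It thereby keeps the aryl group of compound 2 and takes the linkage of compound 1. Among the compounds with values here, the step of a number 44 percentage points lower from compound 1 to compound 2 (beyond the scatter) bears on it only in part, and no measured pair isolates the arylamino-to-aryl exchange on the carbonyl carbon. The expected outcome is a step in the weakening direction, a number 22.9 percentage points higher from compound 2 to compound 3 (beyond the scatter), landing somewhere between the two measured values, with considerable uncertainty. Compound 3 is estimated in this assay at 15%, with a range from -10% to 40%.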

Compound 3, a percentage reported as activity, at one concentration (the size of the read-out at that concentration, not a potency): 37.9%
Estimate against measurement, compound 3: 22.9 percentage points below; low and high end bracket the measured number.
By their numbers in this assay, from the lowest: compound 2; then compounds 1 and 3 (each within the scatter of the next).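

In this assay, the exchange on the carbonyl carbon can now be read on its own: with the 3-(trifluoromethyl)phenyl group held constant, replacing (3-(trifluoromethyl)phenyl)amino with 3-(trifluoromethyl)phenyl gives a number 45.8 percentage points higher from compound 2 to compound 3 (beyond the scatter). The aryl exchange can also be read separately, and with the linkage held constant it gives a number 1.8 percentage points higher from compound 1 to compound 3 (within the scatter), so these compounds show no separation between 3,4-dichlorophenyl and 3-(trifluoromethyl)phenyl at this position, and the large difference between compound 1 and compound 2 tracks the arylamino group among the compounds shown. No evidence is available that accounts for this difference in terms of the amino nitrogen, its hydrogen or any other feature of the group.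

The compounds shown leave open whether the arylamino effect carries over to other aryl groups, as a (3,4-dichlorophenyl)amino group on the same carbonyl carbon would test. They also leave open whether the nitrogen can be exchanged, for example for the oxygen of a phenoxy group or the carbon of a benzyl group, or capped as an N-methyl-N-arylamino group.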